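The source may report more compounds than this note shows. Statements on the series, on what has been measured and on what is new or still open speak of the compounds shown alone.

Compounds measured in an ADME assay on L132 cells (Homo sapiens) for cytotoxicity, read by MTT assay, with a stated time of 48 h; a lower number here means a stronger inhibitor, a higher number a weaker inhibitor:

Compound 1 `C/C(=C\CC/C(C)=C/CC[C@@H]1[C@@]2(C)CCC(=O)C(C)(C)[C@H]2CC[C@@]1(C)O)CC/C=C(\C)C(=O)OCc1cn(-c2cccc(O)c2)nn1`: 146000 nM
Compound 2 `C/C(=C\CC/C(C)=C/CC[C@@H]1[C@@]2(C)CCC(=O)C(C)(C)[C@H]2CC[C@@]1(C)O)CC/C=C(\C)C(=O)OCc1cn(-c2ccc(C(F)(F)F)cc2)nn1`: in this assay compound 2 gives only a limit, > 150000 nM
Compound 3 `C/C(=C\CC/C(C)=C/CC[C@@H]1[C@@]2(C)CCC(=O)C(C)(C)[C@H]2CC[C@@]1(C)O)CC/C=C(\C)C(=O)OCc1cn(-c2ccc([N+](=O)[O-])cc2)nn1`: in this assay compound 3 gives only a limit, > 150000 nM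

Compound 2 stands at the limit of this assay, not at a number; (the limit of > 150000 nM in this assay, at which 2 of the 3 values shown sit). Among the compounds with values here, the only step leading to it is an at least 1.0-fold higher number from compound 1 to compound 2 (0.01 log units; that floor lies within the scatter), which carries the exchange of 4-(trifluoromethyl)phenyl for 3-hydroxyphenyl on the aromatic nitrogen. The step that the two limits leave unreadable from compound 2 to compound 3 sits between two limits and gives no size. Nothing among the three compounds separates them beyond the scatter.

Compound 4 `C/C(=C\CC/C(C)=C/CC[C@@H]1[C@@]2(C)CCC(=O)C(C)(C)[C@H]2CC[C@@]1(C)O)CC/C=C(\C)C(=O)OCc1cn(-c2ccc(Cl)cc2)nn1` is the untested member. Its difference from compound 2: chloro in place of trifluoromethyl on an aromatic carbon.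

Within the data shown here, no measured step bears directly on this change. Among the measured compounds shown here, the steps that touch the aryl group on the triazole nitrogen, an at least 1.0-fold higher number from compound 1 to compound 2 (0.01 log units; that floor lies within the scatter) and a step that the two limits leave unreadable from compound 2 to compound 3, show only that compound 2 and compound 3 reach the limit while compound 1 sits close under it. On that basis compound 4 is expected to behave like compound 2, with a step of a number no higher from compound 2 to compound 4 (the limit leaves the size open) that stays within the scatter, and most likely again to return a limit rather than a number. The estimate for compound 4 is 150000 nM, between 75000 nM and 300000 nM.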

Compound 4, half-maximal inhibitory concentration: > 150000 nM
Compound 4 was reported as a limit; the forecaster's own chance of this, stated with the estimate: 60%; the middle value lies on the limit itself.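

In this assay, chloro on the aromatic carbon para to a large group gives no number, and compound 4 returns only a limit, > 150000 nM. The exchange of trifluoromethyl, with its 4 heavy atoms, for chloro, with 1 heavy atom, therefore leaves the reading unchanged, and the para-substituted aryl groups now include trifluoromethyl, nitro and chloro, all reported the same way: the limit of > 150000 nM in this assay, at which 3 of the 4 values shown sit.

Within the data shown here, the steps from compound 2 and from compound 3 to compound 4 run between limits and cannot be read, so the only readable step is an at least 1.0-fold higher number from compound 1 to compound 4 (0.01 log units; that floor lies within the scatter), and the 3-hydroxyphenyl of compound 1 is not separated from 4-chlorophenyl beyond the scatter.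

From the compounds shown here alone, whether any group at this position gives a number clearly under that of compound 1, 146000 nM, stays open; an amine or a carboxylic acid on the phenyl ring in place of chloro would address this. The compounds shown also leave open whether changes to the shared core, such as a longer chain between the ester and the aromatic ring, would bring a reading off the limit in this assay.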